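Second trifluoromethyl on the urea aryl of compound 1

The source may hold more compounds than are shown below. What is called first, only, known or untested is meant among the compounds shown, and "the series" means these compounds.

The series shares one core, carrying a urea whose far aryl group varies. For the measured compounds named here, compound 1 `O=C(Nc1cccc(-n2cc(-c3ccncc3)c(-c3ccc(Cl)c(O)c3)n2)c1)Nc1cccc(C(F)(F)F)c1` bears a 3-(trifluoromethyl)phenyl on the urea nitrogen; in a functional assay on MDA-MB-468 cells (Homo sapiens) for inhibition, read by sulforhodamine B assay, with a stated time of 48 h (a lower number here means a stronger inhibitor of growth, a higher number a weaker inhibitor of growth), compound 1 gives 7830 nM, the highest of the two numbers so far. Compound 2 `O=C(Nc1cccc(-n2cc(-c3ccncc3)c(-c3ccc(Cl)c(O)c3)n2)c1)Nc1ccc(Cl)c(Cl)c1`, with 3,4-dichlorophenyl in its place, gives 4250 nM in this assay; the step of a 1.8-fold lower number from compound 1 to compound 2 (0.27 log units; within the scatter) lies within the scatter, so the two values are treated as equal.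

Compound 3 `O=C(Nc1cccc(-n2cc(-c3ccncc3)c(-c3ccc(Cl)c(O)c3)n2)c1)Nc1cc(C(F)(F)F)cc(C(F)(F)F)c1` has not been measured. Its difference from compound 1 is trifluoromethyl in place of hydrogen on an aromatic carbon, on an aromatic carbon of the urea aryl, meta to the trifluoromethyl group already present. Going by the values given here, no measured pair shows this change; the only step on hand, from compound 1 to compound 2, swaps the whole aryl group and stays within the scatter. On that basis a change within the scatter is expected, with the step of a 1.2-fold lower number from compound 1 to compound 3 (0.08 log units; within the scatter) as the estimate. Compound 3 is therefore estimated at 6500 nM in this assay, between 2500 nM and 16000 nM.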

Compound 3, concentration for total growth inhibition: 2660 nM
The estimate for compound 3 lay 2.4-fold (0.39 log units) above the measured number; low and high end bracket the measured number.
By their numbers in this assay, from the lowest: compounds 3, 2 and 1 (each within the scatter of the next, the first and the last beyond it).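

In this assay, adding trifluoromethyl on an aromatic carbon of the urea aryl, meta to the trifluoromethyl group already present, gives a 2.9-fold lower number from compound 1 to compound 3 (0.47 log units; beyond the scatter), a modest step in the direction of stronger growth inhibition. For the compounds shown here, this is the first change to pass the scatter, whereas the exchange of the whole aryl group, a 1.8-fold lower number from compound 1 to compound 2 (0.27 log units; within the scatter), could not show that substitution on this ring moves the number measurably, so this aromatic carbon is now a place where a single added group registers in the read-out. No measured data on hand account for the step, which stands here as an observation only.

The compounds shown leave open whether the step belongs to trifluoromethyl itself or would also appear with another group on the same aromatic carbon, such as a nitrile, an amine or a carboxylic acid. They also leave open whether trifluoromethyl entering at this carbon gives a step of similar size on an aryl group carrying chlorine, as in compound 2, or one carrying no other group.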